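Capping a Carboxylic Acid as a Tert-Butyl Ester

A few compounds are considered here, and "the series" means these few. Any claim that something is new, unique, unknown or untested is made for them only; others in the source may bear on it.

Compound 1 `Cn1cncc1C(O)(c1ccc([N+](=O)[O-])cc1)c1cc2cc([N+](=O)[O-])cc(-c3ccccc3)c2o1`: 547 nM
Compound 2 `Cn1cncc1[C@@](N)(c1ccc(C#N)cc1)c1cc2cc([N+](=O)[O-])cc(-c3ccccc3)c2o1`: 5.9 nM
Compound 3 `Cn1cncc1C(O)(c1ccc(C(=O)O)cc1)c1cc2cc([N+](=O)[O-])cc(-c3ccccc3)c2o1`: its result is a limit of the assay, not a number, > 10000 nM

All three share one core and were tested in a functional assay on QG-56 cells (Homo sapiens) for antiproliferative activity; on this read-out lower numbers stand for stronger inhibition and higher numbers for weaker inhibition. Compound 1 carries a nitro group on the pendant ring; compound 3 carries a carboxy there instead, and that single change gives an at least 18-fold higher number from compound 1 to compound 3 (1.26 log units; beyond the scatter). Compound 3 sits at the limit of > 10000 nM in this assay, at which 1 of the 3 values shown sits, so its value is a limit and only a lower bound is known.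

Compound 4 `Cn1cncc1C(O)(c1ccc(C(=O)OC(C)(C)C)cc1)c1cc2cc([N+](=O)[O-])cc(-c3ccccc3)c2o1` differs from compound 3 by tert-butyl in place of hydrogen on an oxygen next to a carbonyl group. Among the compounds with values here, the only measured step that bears on this position is the large loss seen in going from compound 1 to compound 3, where the carboxy was introduced. Since compound 4 reads as carboxy to tert-butoxycarbonyl, part of that loss is expected to be recovered, though the limit on compound 3 leaves the size uncertain. The expected step is an at least 5.0-fold lower number from compound 3 to compound 4 (0.69 log units; beyond the scatter). Compound 4 is therefore estimated at 2000 nM, within 300 nM to 10000 nM.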

Compound 4, half-maximal inhibitory concentration: 6250 nM
The estimate for compound 4 lay 3.1-fold (0.49 log units) below the measured number; the measured number falls inside the stated range.
By their numbers in this assay, from the lowest: compound 2; then compound 1; then compound 4. At a limit, above all of these: compound 3.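

Compound 4 gives this position its first real number for a group built on the carboxy, yet capping the acid as a tert-butyl ester reads as an at least 1.6-fold lower number from compound 3 to compound 4 (0.20 log units; that floor lies within the scatter), so a true gain from the cap is not established. Compound 3 is a limit of the assay, not a number: the limit of > 10000 nM in this assay, at which 1 of the 4 values shown sits. The clearer finding is that the ester does not restore what the nitro group gives, since the swap of nitro for tert-butoxycarbonyl still leaves an 11-fold higher number from compound 1 to compound 4 (1.06 log units; beyond the scatter) as a real loss.

As far as these compounds go, whether a methyl ester or a primary amide at this place would come closer to compound 1 stays open. The compounds shown also cannot say how much of the loss depends on the tert-butyl group itself rather than on the carbonyl beneath it.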